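The source may report more compounds than this note shows. Statements on the series, on what has been measured and on what is new or still open speak of the compounds shown alone.

Measured so far in an ADME assay for permeability, using PAMPA, at pH 7.4; on this read-out lower numbers stand for lower permeability and higher numbers for higher permeability:
Compound 1, `COc1cccc2c(=O)c(Cc3ccccc3)c(C)[nH]c12`, gives 125 10^-6 cm/s.
Compound 2, `Cc1[nH]c2c(Cl)cccc2c(=O)c1Cc1ccccc1`, gives 412 10^-6 cm/s.
Compound 3, `COc1ccc2nc(C)c(Cc3ccccc3)c(OC)c2c1`, gives 1070 10^-6 cm/s.

Compound 4, `COc1c(Cc2ccccc2)c(C)nc2ccc(Cl)cc12`, has not yet been measured in this assay. From compound 1 to compound 2 the change is chloro in place of methoxy on an aromatic carbon and it brought a 3.3-fold higher number from compound 1 to compound 2 (0.52 log units; beyond the scatter). From compound 3 to compound 4 the change is chloro in place of methoxy on an aromatic carbon. The two are the same kind of change, but not the same: in the first pair the chloro sits ortho to a fused ring and meta to a fused ring, in the second pair meta to a fused ring and para to a fused ring. The difference between the core of compound 1 and the core of compound 3 is not broken down here. Compound 3 already stands highest of the three in this assay, well above compound 2 and compound 1. Because the earlier change gave a 3.3-fold higher number from compound 1 to compound 2 (0.52 log units; beyond the scatter), a rise in the same direction is expected for compound 4, but a smaller one, since compound 3 starts from 1070 10^-6 cm/s, a very high reading. For compound 4 the expected step is a 1.6-fold higher number from compound 3 to compound 4 (0.20 log units; within the scatter). Compound 4 is therefore estimated at 1700 10^-6 cm/s, with a range from 800 10^-6 cm/s to 3500 10^-6 cm/s.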

Compound 4, apparent permeability: 268 10^-6 cm/s
Estimate against measurement, compound 4: 6.3-fold (0.80 log units) above; the measured number lies below the stated range.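

In this assay, chloro in place of methoxy on an aromatic carbon gave a 4.0-fold lower number from compound 3 to compound 4 (0.60 log units; beyond the scatter), so the rise seen on the earlier core did not carry over to this one. Set side by side, the two steps run in opposite directions, and the gap between them is larger than repeat measurements would explain: the same change on two cores in this assay, a 3.3-fold higher number (0.52 log units; beyond the scatter) from compound 1 to compound 2 and a 4.0-fold lower number (0.60 log units; beyond the scatter) from compound 3 to compound 4, 13-fold (1.12 log units) apart, beyond the scatter of two such steps. This shows that, in this series, the step measured on one core cannot be taken as a forecast for another, but the two pairs differ both in the core and in the place of the change on the ring, so they do not show which of these matters, or why the number moves.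

The compounds shown leave open how other groups on the same aromatic carbon, such as an amine or a carboxylic acid, would read in this assay. They also leave open whether the swap from methoxy to chloro would go up or down at further places on either core.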